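Chloro added to the pyrimidine amide: compound 3 outlook

The source may hold more compounds than are shown below. What is called first, only, known or untested is meant among the compounds shown, and "the series" means these compounds.

Measured in a functional assay on NCI-H1975 cells (Homo sapiens) for antiproliferative activity, read by MTT assay, with a stated time of 72 h; a higher number here means a weaker inhibitor, a lower number a stronger inhibitor:
compound 1 `COc1cc(N(C)C)c(NC(=O)c2ccnc(Cl)c2)cc1Nc1nccc(-c2cn(C)c3ccccc23)n1` — 9200 nM
compound 2 `COc1cc(N(C)C)c(NC(=O)c2ccncn2)cc1Nc1nccc(-c2cn(C)c3ccccc23)n1` — 1250 nM

Compound 2 gives the lowest of the two numbers in this assay; its nearest neighbour is compound 1, and the step of a 7.4-fold lower number from compound 1 to compound 2 (0.87 log units; beyond the scatter) separates them, beyond the scatter.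

Compound 3 `COc1cc(N(C)C)c(NC(=O)c2ccnc(Cl)n2)cc1Nc1nccc(-c2cn(C)c3ccccc23)n1` is not yet measured. It differs from compound 2 by chloro in place of hydrogen on an aromatic carbon, on an aromatic carbon of a six-membered aromatic ring with two nitrogen, between two ring nitrogen atoms, meta to a large group; read one bond further out, pyrimidin-4-yl becomes 2-chloropyrimidin-4-yl.

Among the measured compounds shown here, only one measured step bears on this, and only loosely: a 7.4-fold lower number from compound 1 to compound 2 (0.87 log units; beyond the scatter) removed a chloro and at the same time exchanged the ring, so the share of the chloro in that step cannot be separated. The chloro-bearing compound 1 has the higher number, which leans the expectation toward a higher number for compound 3 than for compound 2, but by less than the full measured step. The step of a 2.4-fold higher number from compound 2 to compound 3 (0.38 log units; beyond the scatter) is therefore expected to be modest. Compound 3 is estimated at 3000 nM, in a range from 1000 nM to 10000 nM.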

Compound 3, half-maximal inhibitory concentration: 3660 nM
Beside the measured number, compound 3's estimate is 1.2-fold (0.09 log units) below it; the measured number falls inside the stated range.
By their numbers in this assay, from the lowest: compound 2; then compound 3; then compound 1.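

In this assay, among the compounds shown here, the single change of chloro in place of hydrogen, on the aromatic carbon between two ring nitrogen atoms, gives a 2.9-fold higher number from compound 2 to compound 3 (0.47 log units; beyond the scatter) and so shows the effect of the chloro with the ring held constant, which the earlier step could not show. For the compounds shown here, with the chloro kept, 2-chloropyrimidin-4-yl in place of 2-chloropyridin-4-yl gives a 2.5-fold lower number from compound 1 to compound 3 (0.40 log units; beyond the scatter) as a separate effect of the ring exchange, so the two changes combined in a 7.4-fold lower number from compound 1 to compound 2 (0.87 log units; beyond the scatter) each move the number in the same direction, and each of their single steps lies beyond the scatter. No measurement in hand accounts for either single step.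

Going by these compounds, it remains open whether the higher number follows from chloro specifically or from any group other than hydrogen on this carbon, which a fluoro, a methyl, a methoxy or an amine there would help to separate. Also open, on these data alone, is whether the chloro step has a similar size on the 2-chloropyridin-4-yl side of the series, where the counterpart without chloro would be the plain pyridin-4-yl amide.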